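A Third Side Chain Against the Assay Limit

The compounds below may be only part of what the source reports. "The series", "measured", "known", "first", "only" and "open" are said of these compounds alone.

In a functional assay on B16-F10 cells (Mus musculus) for antiproliferative activity, read by CCK-8 assay, with a stated time of 48 h (a higher number here means a weaker inhibitor, a lower number a stronger inhibitor), compound 1 `COc1ccc(/C=C\c2cc(OC)c(OC)c(OC)c2)cc1OCc1ccc(CN2CCCC[C@H]2C(=O)O)cc1` reads > 10000 nM as a limit of the assay and not as a number. Compound 2 `COc1ccc(/C=C\c2cc(OC)c(OC)c(OC)c2)cc1OCc1ccc(CN2CC[C@H](O)C2)cc1` reads > 10000 nM and this too is only a limit, so it has no number of its own. Within the data shown here, the one measured change is a step that the two limits leave unreadable from compound 1 to compound 2 and gives no size to carry forward. All the data show is the limit of > 10000 nM in this assay, at which 2 of the 2 values shown sit, and nothing finer. Compound 3 `COc1ccc(/C=C\c2cc(OC)c(OC)c(OC)c2)cc1OCc1ccc(CN[C@H](C(=O)O)[C@@H](C)O)cc1` brings (1-carboxy-2-hydroxypropyl)amino in place of 3-hydroxypyrrolidin-1-yl on a saturated chain carbon bound to an aromatic carbon with the swap made on a saturated chain carbon bound to an aromatic carbon. Its new group holds a carboxy group, as does compound 1 with its limit of > 10000 nM in the 2-carboxypiperidin-1-yl group. No clear gain is therefore expected in this assay and the estimated step is a step that the limit leaves unreadable from compound 2 to compound 3 with another limit the likeliest report. For compound 3 the estimated value is 12000 nM within an expected range from 4000 nM to 30000 nM in this measurement.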

Compound 3, half-maximal inhibitory concentration: 5400 nM
For compound 3 the middle estimate is 2.2-fold (0.35 log units) above the measured one; measured number inside the range.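

Among these compounds, on a saturated chain carbon bound to an aromatic carbon, the open-chain (1-carboxy-2-hydroxypropyl)amino group gives the first true number in this assay, with compound 3 at (5400 nM). Compound 1 and compound 2 stay at a limit: the limit of > 10000 nM in this assay, at which 2 of the 3 values shown sit. On these data alone, the two readable steps are (an at least 1.8-fold lower number from compound 2 to compound 3 (0.26 log units; that floor lies within the scatter)) and (an at least 1.8-fold lower number from compound 1 to compound 3 (0.26 log units; that floor lies within the scatter)), and each is only a floor, so the real size of the change remains unknown. Compound 1 also carries a carboxy group yet sits at a limit, so among these compounds a carboxy group alone does not decide whether a number can be read.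

As far as these compounds go, it remains open which feature of the new group matters: its carboxy group, its hydroxy group or its lack of a ring. An open-chain amine with neither oxygen group, such as dimethylamino, at the same place would help to separate these.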